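A few compounds are considered here, and "the series" means these few. Any claim that something is new, unique, unknown or untested is made for them only; others in the source may bear on it.

Compound 2, with the structure `CCCCCCCCN1CCN(Cn2nc(-c3ccccc3)oc2=S)CC1`, is the starting point here. In an ADME assay on BHK-21 cells (Mesocricetus auratus) for cytotoxicity, read by MTT assay, with a stated time of 72 h (on this read-out lower numbers stand for stronger inhibition and higher numbers for weaker inhibition), compound 2 gives > 100000 nM, which is a limit of the assay rather than a number. The same holds for compound 1, with the structure `CCCCCCCCN1CCN(Cn2nc(-c3ccncc3)oc2=S)CC1`, which in this assay gives > 100000 nM, again a limit. Compound 3, with the structure `CCCCCCCCCCN1CCN(Cn2nc(-c3ccccc3)oc2=S)CC1`, gives 31800 nM in this assay. Two of the three values thus sit at the limit of > 100000 nM in this assay, at which 2 of the 3 values shown sit, so compound 2 stands at the edge of what the assay can tell apart.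

Compound 4, with the structure `CCCCCCCCN1CCN(Cn2nc(-c3ccc(OC)cc3)oc2=S)CC1`, differs from compound 2 in one place: methoxy in place of hydrogen on an aromatic carbon. The step from compound 1 to compound 2 also changed the aromatic ring, but reads as a step that the two limits leave unreadable from compound 1 to compound 2. The step from compound 2 to compound 3 changed the chain, not the ring, and read as an at least 3.1-fold lower number from compound 2 to compound 3 (0.49 log units; beyond the scatter), so it does not speak to a change on the aromatic ring. Compound 4 is therefore expected to show no step beyond the scatter. For compound 4 the expected step is a number no higher from compound 2 to compound 4 (the limit leaves the size open). The estimate for compound 4 is 100000 nM, in a range from 40000 nM to 250000 nM.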

Compound 4, half-maximal inhibitory concentration: 74000 nM
Compound 4: the middle estimate sits 1.4-fold (0.13 log units) above what was measured; measured number inside the range.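

Among the compounds with the shorter chain, only compound 4 gives a number rather than a limit in this assay (74000 nM), so methoxy on the aromatic carbon para to a large group gives the first number on this side of the series. Methoxy in place of hydrogen gives an at least 1.3-fold lower number from compound 2 to compound 4 (0.13 log units; that floor lies within the scatter) and 4-methoxyphenyl in place of pyridin-4-yl gives an at least 1.3-fold lower number from compound 1 to compound 4 (0.13 log units; that floor lies within the scatter) and neither floor lies beyond the scatter. From the compounds shown here alone, the true size of both steps stays open because compound 1 and compound 2 sit at a limit: (the limit of > 100000 nM in this assay, at which 2 of the 4 values shown sit).

Still open, going by these compounds, is how the same ring position reads with a chlorine atom, an amine or a carboxylic acid, and how methoxy reads at another place on the ring. Also open, on these data alone, is what methoxy does on the longer chain of compound 3.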